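The compounds below may be only part of what the source reports. "The series", "measured", "known", "first", "only" and "open" are said of these compounds alone.

Measured so far:
- compound 1 `Nc1ccc(S(=O)(=O)c2ccc(-c3ncc(C(O)(C(F)(F)F)C(F)(F)F)cc3C#CCO)cc2)cn1`: 36 mL.min-1.g-1
- compound 2 `CC(C)(O)C#Cc1cc(C(O)(C(F)(F)F)C(F)(F)F)cnc1-c1ccc(S(=O)(=O)c2ccc(N)nc2)cc1`: < 14 mL.min-1.g-1
- compound 3 `CNc1nc(S(=O)(=O)c2ccc(N)nc2)ccc1-c1ccc(C(C)(O)C(F)(F)F)cn1`: 21 mL.min-1.g-1

All three were tested in an ADME assay (liver) for metabolic stability, with Liver microsome (Rattus norvegicus) as the target, using microsomes and NADPH, with a stated time of 30 min, at 37 degrees C, tested at 1 uM; a lower number here means slower removal, a higher number faster removal of the compound. For compound 2, < 14 mL.min-1.g-1 is a limit of the assay and not a number. Within the data shown here, only two compounds have true numbers: compound 3 at 21 mL.min-1.g-1 and compound 1 at 36 mL.min-1.g-1, which lie within the usual scatter of each other.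

Compound 4 `CC(O)(c1ccc(-c2ccc(S(=O)(=O)c3ccc(N)nc3)nc2Nc2ccccc2)nc1)C(F)(F)F` is derived from compound 3 by one change, phenyl in place of methyl on a nitrogen on an aromatic ring. Among the measured compounds shown here, no measured step makes this change. For the measured compounds named here, the only step available, an at least 2.5-fold lower number from compound 1 to compound 2 (0.41 log units; beyond the scatter), concerns a different group on a triple-bonded carbon, so it gives only a rough idea of how large one change can be in this assay.

A step clearly beyond the scatter is therefore not expected, although the direction is uncertain and the range must stay wide. The expected change is a 1.3-fold higher number from compound 3 to compound 4 (0.12 log units; within the scatter). The estimate for compound 4 is 28 mL.min-1.g-1, with an expected range from 12 mL.min-1.g-1 to 65 mL.min-1.g-1.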

Compound 4, intrinsic clearance in microsomes: 100 mL.min-1.g-1
Beside the measured number, compound 4's estimate is 3.6-fold (0.55 log units) below it; measured number outside the range, above it.
By their numbers in this assay, from the lowest: compounds 3 and 1 (each within the scatter of the next); then compound 4. At a limit, below all of these: compound 2.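

In this assay, the nitrogen on an aromatic ring turns out to be a place where the group matters: replacing methylamino with anilino gives a 4.8-fold higher number from compound 3 to compound 4 (0.68 log units; beyond the scatter) and so moves the compound towards faster removal. Among these compounds, the earlier compounds showed only a change on a triple-bonded carbon, which lowered the number, so this is the first sign that a single change can also raise it clearly. Nothing measured here explains the rise.

With a single pair, the compounds shown leave open whether the rise follows the larger size of the group or the presence of its aromatic ring. A plain amine, an ethyl group or a cyclohexyl group on this nitrogen would help to tell these two readings apart.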